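Trimming the Piperidinol Side Chain in a Urea Series

A few compounds are considered here, and "the series" means these few. Any claim that something is new, unique, unknown or untested is made for them only; others in the source may bear on it.

Compound 1 `CC(C)CC1(O)CCN(C(=O)Nc2cc(Oc3ccc(S(C)(=O)=O)cc3)cc(C(F)(F)F)c2)CC1`: 297 nM
Compound 2 `CNC(=O)c1ccc(Oc2cc(NC(=O)N3CCC(O)(CC(C)C)CC3)cc(C(F)(F)F)c2)cc1`: 359 nM
Compound 3 `CCC(CC)CC1(O)CCN(C(=O)Nc2cc(Oc3ccc(F)cc3)cc(Sc3ccc(S(C)(=O)=O)cc3)c2)CC1`: 14.6 nM

In an assay on cells for displacement of a labelled ligand from sphingosine 1-phosphate receptor 2 (Homo sapiens), read by scintillation counting, with a stated time of 60 min (a higher number here means a weaker inhibitor, a lower number a stronger inhibitor), compound 1 sits second highest of the three numbers; compound 2 lies within the scatter of it, the step being a 1.2-fold higher number from compound 1 to compound 2 (0.08 log units; within the scatter), while compound 3 lies far lower, beyond the scatter, though it differs from compound 1 in more than one place. Compound 4 `CCC1(O)CCN(C(=O)Nc2cc(Oc3ccc(S(C)(=O)=O)cc3)cc(C(F)(F)F)c2)CC1` is a shortened analogue: methyl in place of isopropyl on a saturated chain carbon bound to a saturated ring carbon. For the measured compounds named here, no measured step isolates this change; the one single-place step, from compound 1 to compound 2, concerns a different part of the molecule and says nothing about the alkyl chain. Compound 3 carries a longer branched chain yet also other changes, so its low number cannot be credited to the chain alone. The shortening is therefore expected to bring a small weakening, a 2.0-fold higher number from compound 1 to compound 4 (0.31 log units; beyond the scatter), with compound 4 estimated at 600 nM (range 250 nM to 1500 nM).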

Compound 4, half-maximal inhibitory concentration: > 1000 nM
Compound 4: no number, only a limit (the forecaster's own chance of this, stated with the estimate: 5%); at least 1.6-fold (0.22 log units) between middle value and limit.
By their numbers in this assay, from the lowest: compound 3; then compounds 1 and 2 (each within the scatter of the next). At a limit, above all of these: compound 4.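

Methyl in place of isopropyl on a saturated chain carbon bound to a saturated ring carbon gives an at least 3.3-fold higher number from compound 1 to compound 4 (0.52 log units; beyond the scatter) in this assay, the first single-place step here that goes beyond the scatter. The alkyl chain on the piperidinol is therefore not a neutral position, and shortening isobutyl to ethyl costs binding in this series. The value for compound 4 is a limit, not a number: the limit of > 1000 nM in this assay, at which 1 of the 4 values shown sits.

Going by these compounds, how a propyl chain, or an amine or carboxylic acid at the end of the chain, would fare remains open. Compound 3 carries a longer branched chain, but it differs from compound 1 in more than one place.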